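The compounds below may be only part of what the source reports. "The series", "measured", "known", "first", "only" and "open" are said of these compounds alone.

Compound 1 `COc1cc(-c2ccnc3cc(-c4ccccc4)nn23)cc(OC)c1OC`: 208 nM
Compound 2 `COc1cc(-c2ccnc3cc(-c4cn(C(=O)OC(C)(C)C)c5ccccc45)nn23)cc(OC)c1OC`: 2070 nM
Compound 3 `COc1cc(-c2ccnc3cc(-c4cn(CO)c5ccccc45)nn23)cc(OC)c1OC`: 167 nM

All three were tested in a functional assay on A549 cells (Homo sapiens) for inhibition, read by CCK-8 assay, with a stated time of 48 h; on this read-out higher numbers stand for weaker inhibition and lower numbers for stronger inhibition. Compound 1 gives the second highest of the three numbers; compound 3 sits within the scatter of it, while compound 2 lies beyond the scatter. For the measured compounds named here, the only measured step between neighbours, a 12-fold lower number from compound 2 to compound 3 (1.09 log units; beyond the scatter), concerns a change on the aromatic nitrogen and is of a different kind.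

Compound 4 `C=Cc1ccc(-c2cc3nccc(-c4cc(OC)c(OC)c(OC)c4)n3n2)cc1` differs from compound 1 by vinyl in place of hydrogen on an aromatic carbon. Going by the values given here, no measured step bears on this change, so in this assay no step beyond the scatter is expected in either direction. Compound 4 is therefore estimated at 200 nM, in the range 80 nM to 500 nM, meaning an expected step of a 1.0-fold lower number from compound 1 to compound 4 (0.02 log units; within the scatter).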

Compound 4, half-maximal inhibitory concentration: 1030 nM
Compound 4: middle estimate off by 5.2-fold (0.71 log units), on the low side, and the stated range ends below it.
By their numbers in this assay, from the lowest: compounds 3 and 1 (each within the scatter of the next); then compounds 4 and 2 (each within the scatter of the next).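

In this assay, the phenyl ring of compound 1 proves sensitive to change at the carbon para to a large group: phenyl to 4-vinylphenyl gives a 5.0-fold higher number from compound 1 to compound 4 (0.69 log units; beyond the scatter), so even this small addition weakens inhibition. The earlier step concerned only an aromatic nitrogen and said nothing about this ring.

On these data alone, whether an ethyl, a methoxy or an amine at this carbon would weaken inhibition in the same way remains open. No measurement at hand accounts for the loss.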